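The source may hold more compounds than are shown below. What is called first, only, known or untested is meant among the compounds shown, and "the series" means these compounds.

Measured in an assay on HEK293 cells for displacement of a labelled ligand from NPC1-like intracellular cholesterol transporter 1 (Homo sapiens); a higher number here means a weaker inhibitor, a lower number a stronger inhibitor:
compound 1 `CC(C)(C)c1ccc(C(=O)N2CCC3(CC2)C(=O)N(CC(=O)N2CCNCC2)CN3c2ccccc2)cc1` gives 22000 nM;
compound 2 `CC(C)(C)OC(=O)NCCNC(=O)CN1CN(c2ccccc2)C2(CCN(C(=O)c3ccc(C(C)(C)C)cc3)CC2)C1=O` gives 10900 nM;
compound 3 `CC(C)(C)OC(=O)NCCCCNC(=O)CN1CN(c2ccccc2)C2(CCN(C(=O)c3ccc(C(C)(C)C)cc3)CC2)C1=O` gives "not determined" (no result reported), so no number is reported for it.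

Compound 2 has the lowest of the two numbers, yet the gap to the other is only a 2.0-fold lower number from compound 1 to compound 2 (0.30 log units; within the scatter), so no order between them can be claimed. Compound 4 `CC1(C)CC(OC(=O)CN2CN(c3ccccc3)C3(CCN(C(=O)c4ccc(C(C)(C)C)cc4)CC3)C2=O)CC(C)(C)N1` differs from compound 2 by (2,2,6,6-tetramethylpiperidin-4-yl)oxy in place of (2-((tert-butoxycarbonyl)amino)ethyl)amino on a carbonyl carbon. Among the measured compounds shown here, the only measured step at this carbonyl carbon, a 2.0-fold lower number from compound 1 to compound 2 (0.30 log units; within the scatter), lies within the scatter, and compound 3 offers no number, so nothing beyond the scatter is expected in this assay for compound 4, in either direction. The estimate for compound 4 is 10000 nM, range 3000 nM to 40000 nM, which means an expected step of a 1.1-fold lower number from compound 2 to compound 4 (0.04 log units; within the scatter).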

Compound 4, half-maximal inhibitory concentration: 1300 nM
Estimate against measurement, compound 4: 7.7-fold (0.89 log units) above, outside the stated range (below it).
By their numbers in this assay, from the lowest: compound 4; then compounds 2 and 1 (each within the scatter of the next).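

Among the compounds shown here, at this carbonyl carbon, the group changes the result in this assay: (2,2,6,6-tetramethylpiperidin-4-yl)oxy gives an 8.4-fold lower number from compound 2 to compound 4 (0.92 log units; beyond the scatter) and a 17-fold lower number from compound 1 to compound 4 (1.23 log units; beyond the scatter), the first steps beyond the scatter. Both steps change the link to the carbonyl and bring in a six-membered non-aromatic ring with 1 hetero atom, so the two changes cannot be separated. No measurement shown explains the gain.

Going by these compounds, whether the step belongs to the oxygen link or to the ring remains open. A (2,2,6,6-tetramethylpiperidin-4-yl)amino group on the same carbonyl carbon would test the link, and a cyclohexyloxy group would test the ring nitrogen.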